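Methoxy for chloro on the anilino ring of compound 3

The source may report more compounds than this note shows. Statements on the series, on what has been measured and on what is new or still open speak of the compounds shown alone.

Compound 1 `O=C(/C=C\Nc1ccc(Cl)cc1)c1cn(-c2ccccc2)nc1-c1ccccc1`, compound 2 `O=C(/C=C\Nc1ccc(O)cc1)c1cn(-c2ccccc2)nc1-c1ccccc1` and compound 3 `O=C(/C=C\Nc1ccc(Cl)cc1)c1cn(-c2ccccc2)nc1-c1ccc(F)cc1` share one core and differ only in the groups on their aromatic rings. In a functional assay on HT-29 cells (Homo sapiens) for antiproliferative activity, read by MTT assay, with a stated time of 48 h (a higher number here means a weaker inhibitor, a lower number a stronger inhibitor), compound 1 gives 3610 nM, compound 2 gives 5000 nM, and compound 3 gives 4600 nM. Compound 3 stands second highest of the three numbers; its nearest neighbour is compound 2 and its furthest is compound 1, and both gaps lie within the scatter. Compound 4 `COc1ccc(N/C=C\C(=O)c2cn(-c3ccccc3)nc2-c2ccc(F)cc2)cc1` is not yet measured. It differs from compound 3 by methoxy in place of chloro on an aromatic carbon. The step that bears most directly on this is a 1.4-fold higher number from compound 1 to compound 2 (0.14 log units; within the scatter), where the same chloro was exchanged at the same place and the number barely moved. The other step, a 1.3-fold higher number from compound 1 to compound 3 (0.11 log units; within the scatter), also stayed within the scatter. On this basis no step beyond the scatter is expected in this assay, and the estimated step is a 1.0-fold higher number from compound 3 to compound 4 (0.02 log units; within the scatter). For compound 4 the estimate in this assay is 4800 nM, with a range from 2000 nM to 11000 nM.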

Compound 4, half-maximal inhibitory concentration: 3200 nM
Estimate against measurement, compound 4: 1.5-fold (0.18 log units) above, and the stated range covers the measured number.
By their numbers in this assay, from the lowest: compounds 4, 1, 3 and 2 (each within the scatter of the next).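

In this assay the change is a 1.4-fold lower number from compound 3 to compound 4 (0.16 log units; within the scatter) and so adds a second exchange of chloro at this place, on an aromatic carbon para to a large group, alongside a 1.4-fold higher number from compound 1 to compound 2 (0.14 log units; within the scatter) with hydroxy as the entering group. Methoxy and hydroxy both leave the number within the scatter of the chloro compound, even though the methoxy exchange is read with fluoro on the core and the hydroxy exchange without it. No measurement shown offers an explanation for either step.

The compounds shown leave open whether an amine, a carboxylic acid or a longer chain such as ethoxy at this place would give a step beyond the scatter. They also leave open how methoxy reads on the core of compound 1, with hydrogen in place of fluoro.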